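The source may hold more compounds than are shown below. What is called first, only, known or untested is meant among the compounds shown, and "the series" means these compounds.

In a functional assay on MCF7 cells (Homo sapiens) for antiproliferative activity, read by MTT assay, with a stated time of 72 h (on this read-out higher numbers stand for weaker inhibition and lower numbers for stronger inhibition), three compounds sharing one core have been measured. Compound 1 (`CCCSc1nc(N/N=C/c2ccc(C)cc2)c2nnn(Cc3ccccc3)c2n1`) gives only a limit, > 64000 nM. Compound 2 (`CCCSc1nc(N/N=C/c2cccs2)c2nnn(Cc3ccccc3)c2n1`) also gives only a limit, > 64000 nM. Compound 3 (`CCCSc1nc(N/N=C/c2ccc(N(C)C)cc2)c2nnn(Cc3ccccc3)c2n1`) alone gives a number, 12200 nM, and is the most potent of the three. Compound 4 (`CCCSc1nc(N/N=C/c2ccccc2F)c2nnn(Cc3ccccc3)c2n1`) carries 2-fluorophenyl in place of 4-(dimethylamino)phenyl on a carbon with a double bond to nitrogen. Within the data shown here, two measured steps bear on this change, an at least 5.2-fold lower number from compound 1 to compound 3 (0.71 log units; beyond the scatter) and an at least 5.2-fold lower number from compound 2 to compound 3 (0.71 log units; beyond the scatter), and both lie beyond the scatter. Like compound 1 and compound 2, compound 4 has no dimethylamino group, so a return towards the limit is expected in this assay. The expected change is a 4.1-fold higher number from compound 3 to compound 4 (0.61 log units; beyond the scatter). For compound 4 the estimated value is 50000 nM, with an expected range of 18000 nM to 100000 nM.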

Compound 4, half-maximal inhibitory concentration: > 64000 nM
Compound 4 gave a limit, no number; the forecaster's own chance of this, stated with the estimate: 60%; middle value at least 1.2-fold (0.10 log units) away from the limit.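

In this assay, 2-fluorophenyl in place of 4-(dimethylamino)phenyl gives an at least 5.2-fold higher number from compound 3 to compound 4 (0.71 log units; beyond the scatter), so a third group at this position without dimethylamino also fails to give a number. Compound 4 joins compound 1 and compound 2 at a limit rather than a number: the limit of > 64000 nM in this assay, at which 3 of the 4 values shown sit. The steps from compound 1 and compound 2 to compound 4 cannot be read, as each joins two limits. As far as these compounds go, it remains open whether a 4-aminophenyl or 4-(diethylamino)phenyl group would also give a number. How far potency could rise at this position is also unknown.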